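Straightening a branched ester chain on the shared core

A few compounds are considered here, and "the series" means these few. Any claim that something is new, unique, unknown or untested is made for them only; others in the source may bear on it.

Three compounds share one core and differ only in the alcohol part of the ester. Compound 1 `CCCCOC(=O)C(O)Cn1cnc2c(N)ncnc21` carries a butyl ester, compound 2 `CC(C)CCOC(=O)C(O)Cn1cnc2c(N)ncnc21` an isopentyl ester, and compound 3 `Nc1ncnc2c1ncn2CC(O)C(=O)OCCO` a hydroxyethyl ester. In a functional assay on HeLa cells (Homo sapiens) for cytotoxicity (on this read-out higher numbers stand for lower toxicity in this test and lower numbers for higher toxicity in this test), compound 1 gives 400 ug/mL and compound 2 gives 400 ug/mL, so compound 2 stands level with compound 1 at the digits shown. For compound 3 the result in this assay is only a limit of the test, > 400 ug/mL. The step from no change at the digits printed from compound 1 to compound 2 (within the scatter) shows that adding a methyl branch to the chain left the read-out unchanged, and the steps of a number no lower from compound 1 to compound 3 (the limit leaves the size open) and a number no lower from compound 2 to compound 3 (the limit leaves the size open) run into the limit (the limit of > 400 ug/mL in this assay, at which 1 of the 3 values shown sits), so their size cannot be read.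

Compound 4 `CCCCCOC(=O)C(O)Cn1cnc2c(N)ncnc21` is the pentyl ester. It differs from compound 2 by propyl in place of isopropyl on a saturated chain carbon, two bonds along the chain from an oxygen next to a carbonyl group: the same atoms are simply joined into a straight chain rather than a branched one, at the same place on the chain. Going by the values given here, the one readable step, from compound 1 to compound 2, changed nothing within the scatter, and it too altered only the shape of this chain. A change beyond the scatter in this assay is therefore not expected; compound 4 is expected to give about 400 ug/mL, between 200 ug/mL and 800 ug/mL, a step of no change at the digits printed from compound 2 to compound 4 (within the scatter) from compound 2.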

Compound 4, minimum cytotoxic concentration: > 400 ug/mL
Compound 4 ended at the assay's limit (the forecaster's own chance of this, stated with the estimate: 35%); the middle value sits exactly at the limit.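

In this assay compound 4 gives > 400 ug/mL, which is a limit of the test and not a number. None of the steps that join compound 4 to compound 1, compound 2 and compound 3 can be read in size. There is a number no lower from compound 2 to compound 4 (the limit leaves the size open) when the same atoms are joined into a propyl rather than an isopropyl at this place on the chain, and a number no lower from compound 1 to compound 4 (the limit leaves the size open) when methyl takes the place of hydrogen on a saturated chain carbon, four bonds along the chain from an oxygen next to a carbonyl group. What is new is that the limit is no longer reached only by compound 3, whose chain carries a hydroxy group, since compound 4, with its plain pentyl chain, reaches it too: the limit of > 400 ug/mL in this assay, at which 2 of the 4 values shown sit.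

The compounds shown leave open how far the true values of compound 3 and compound 4 lie past the limit, and so whether straightening the chain moves the read-out beyond the usual scatter at all. As far as these compounds go, it also stays open whether a longer chain such as hexyl, or an amine at the end of the ester chain, would give a value that can be read at this place.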